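Hexyloxy to ethoxy on the shared core

The source may report more compounds than this note shows. Statements on the series, on what has been measured and on what is new or still open speak of the compounds shown alone.

Measured so far in a functional assay on A549 cells (Homo sapiens) for antiproliferative activity, read by MTT assay, with a stated time of 48 h; a lower number here means a stronger inhibitor, a higher number a weaker inhibitor
- compound 1 `COc1ccc(/C=C/c2cc(OC)cc(OC)c2/C=C/C(=O)c2cccc(OC)c2)cc1` gives 6.1 ug/mL
- compound 2 `COc1ccc(/C=C/c2cc(OC)cc(OC)c2/C=C/C(=O)c2cccc(Br)c2)cc1` gives 8.1 ug/mL
- compound 3 `CCCCCCOc1ccc(C(=O)/C=C/c2c(/C=C/c3ccc(OC)cc3)cc(OC)cc2OC)cc1` gives 8.4 ug/mL

Compound 3 at 8.4 ug/mL lies within the scatter of both other compounds, so the three numbers show no order. Compound 4 `CCOc1ccc(C(=O)/C=C/c2c(/C=C/c3ccc(OC)cc3)cc(OC)cc2OC)cc1` is the next case. The change is hydrogen in place of butyl on a saturated chain carbon, two bonds along the chain from an oxygen on an aromatic ring, which also reads as hexyloxy to ethoxy.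

Going by the values given here, only one measured step bears on this, and only indirectly: a 1.3-fold higher number from compound 1 to compound 2 (0.12 log units; within the scatter), for bromo in place of methoxy on an aromatic carbon. It is a different change and stays within the scatter. Among the compounds with values here, no measured step covers a change of chain length, so the basis is thin. The expected result is a 1.1-fold lower number from compound 3 to compound 4 (0.05 log units; within the scatter), with no shift beyond the scatter anticipated in either direction. In this assay compound 4 is estimated at 7.5 ug/mL, with 4 ug/mL to 14 ug/mL as the expected range.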

Compound 4, half-maximal inhibitory concentration: 7.5 ug/mL
Beside the measured number, compound 4's estimate shows no gap at the digits printed; low and high end bracket the measured number.
By their numbers in this assay, from the lowest: compounds 1, 4, 2 and 3 (each within the scatter of the next).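

In this assay, cutting hexyloxy to ethoxy on the shared core gives a 1.1-fold lower number from compound 3 to compound 4 (0.05 log units; within the scatter), the first step measured at this chain position, so going from hexyl to ethyl here produces no shift beyond the scatter. Exchanges of the whole aryl group on the carbonyl carbon read the same way, with a 1.1-fold lower number from compound 2 to compound 4 (0.03 log units; within the scatter) and a 1.2-fold higher number from compound 1 to compound 4 (0.09 log units; within the scatter), so 4-ethoxyphenyl is not separated from 3-bromophenyl or 3-methoxyphenyl. No measured evidence on the reason for these results is available for the series.

Still open, going by these compounds, is whether a chain longer than hexyl, or a terminal amine or carboxylic acid on the chain, would move the number beyond the scatter. Also open, on these data alone, is whether a free hydroxy group in place of ethoxy would do so.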